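The source may hold more compounds than are shown below. What is called first, only, known or untested is meant among the compounds shown, and "the series" means these compounds.

Three compounds have been measured in an assay on CHO cells for displacement of a labelled ligand from 5-hydroxytryptamine receptor 1D (Homo sapiens); on this read-out lower numbers stand for stronger inhibition and higher numbers for weaker inhibition:

- compound 1 `c1ccc(C2CCCCN2C2CCN(CCCc3c[nH]c4ccc(-n5cnnc5)cc34)CC2)cc1` gives 1.9 nM
- compound 2 `CC(C)=CCCN(C)C1CCN(CCCc2c[nH]c3ccc(-n4cnnc4)cc23)CC1` gives 2.6 nM
- compound 3 `CN(Cc1ccccc1)CC1CCN(CCCc2c[nH]c3ccc(-n4cnnc4)cc23)CC1` gives 0.9 nM

Compound 2 has the highest number of the three in this assay. Compound 1 lies within the scatter of it, so the two cannot be told apart. Going by the values given here, compound 3 is the only measured compound that sits clearly apart, with a 2.9-fold lower number from compound 2 to compound 3 (0.46 log units; beyond the scatter); that step replaces the whole side group on the saturated ring carbon with (benzyl(methyl)amino)methyl.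

Compound 4 `CC(C)=CCN(C)C1CCN(CCCc2c[nH]c3ccc(-n4cnnc4)cc23)CC1` keeps everything in compound 2 except one change: 2-methylprop-1-en-1-yl in place of 3-methylbut-2-en-1-yl on a saturated chain carbon bound to an amine nitrogen. Among the compounds with values here, this removes a single carbon from the chain; no measured pair shows a change of that kind, since the step from compound 2 to compound 3 swaps a much larger group. Within the data shown here, with no comparable step to lean on, the expectation is that compound 4 stays close to compound 2. The expected step is a 1.2-fold higher number from compound 2 to compound 4 (0.06 log units; within the scatter), not beyond the scatter. Compound 4 is therefore estimated at 3 nM, within a range of 1.2 nM to 8 nM.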

Compound 4, half-maximal inhibitory concentration: 0.5 nM
Estimate against measurement, compound 4: 6.0-fold (0.78 log units) above; measured number outside the range, below it.
By their numbers in this assay, from the lowest: compounds 4 and 3 (each within the scatter of the next); then compounds 1 and 2 (each within the scatter of the next).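

Removing one carbon from the chain on the amine nitrogen, going from 4-methylpent-3-en-1-yl to 3-methylbut-2-en-1-yl, is not a neutral change in this assay, since it gives a 5.2-fold lower number from compound 2 to compound 4 (0.72 log units; beyond the scatter) and so shows that this position responds to a very small edit. The shorter chain, which has no ring, also brings the compound level with the benzyl-bearing side group, with a 1.8-fold lower number from compound 3 to compound 4 (0.26 log units; within the scatter) leaving the two impossible to tell apart. Nothing available explains why removing one carbon has an effect of this size.

Going by these compounds alone, with only two chain lengths compared in one place, it remains open whether a still shorter group, such as a plain ethyl, would continue the change. A saturated 3-methylbutyl chain would be needed to show whether the double bond matters.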